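A few compounds are considered here, and "the series" means these few. Any claim that something is new, unique, unknown or untested is made for them only; others in the source may bear on it.

Compound 1 `C#CCOc1ccc(C(=O)c2ccc(Cn3ccnc3)cc2)cc1`: in an assay on isolated protein for inhibition of Aromatase (Homo sapiens), read by fluorescence, with stated times of 10 min and 60 min (a lower number here means a stronger inhibitor, a higher number a weaker inhibitor), compound 1 gives 210 nM
Compound 2 `CCCCCOc1ccc(C(=O)c2cccc(Cn3ccnc3)c2)cc1`: compound 2 gives 42 nM
Compound 3 `CCCOc1ccc(C(=O)c2ccc(Cn3ccnc3)cc2)cc1`: compound 3 gives 374 nM

Compound 3 carries the highest of the three numbers. From compound 1 it is separated only by a 1.8-fold higher number from compound 1 to compound 3 (0.25 log units; within the scatter), so the two stand together rather than apart. Among the compounds with values here, compound 2 differs from compound 3 in two places and shows a much lower number; no single-change step joins them, so only the two values can be set side by side.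

Compound 4 `CCCCCOc1ccc(C(=O)c2ccc(Cn3ccnc3)cc2)cc1` is compound 3 with ethyl in place of hydrogen on a saturated chain carbon, three bonds along the chain from an oxygen on an aromatic ring. Within the data shown here, the one measured single step, a 1.8-fold higher number from compound 1 to compound 3 (0.25 log units; within the scatter), concerns the chain carbon bound to the aromatic oxygen and lay within the scatter; it does not speak directly to lengthening the chain at the carbon three bonds along. Compound 2 shows that a pentyl chain is compatible with a low number, but its second difference leaves the share of the chain open. The step of a 2.5-fold lower number from compound 3 to compound 4 (0.40 log units; beyond the scatter) is therefore expected to be small, toward a lower number in this assay if anything. Compound 4 is estimated at 150 nM, with a range from 50 nM to 450 nM.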

Compound 4, half-maximal inhibitory concentration: 1300 nM
For compound 4 the middle estimate is 8.7-fold (0.94 log units) below the measured one; measured number above the stated range.
By their numbers in this assay, from the lowest: compound 2; then compounds 1 and 3 (each within the scatter of the next); then compound 4.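

In this assay, within the data shown here, extending the chain at this carbon, three bonds along from an oxygen on an aromatic ring, gives a 3.5-fold higher number from compound 3 to compound 4 (0.54 log units; beyond the scatter) and thus the first change on this core that lies beyond the scatter, while the butyl for ethynyl exchange gives a 6.2-fold higher number from compound 1 to compound 4 (0.79 log units; beyond the scatter) in the same direction. The pentyl chain alone does not go with a low number: compound 2 gives 42 nM and compound 4 gives 1300 nM with the same chain, so the low value of compound 2 stays with its different core. Nothing measured here accounts for the rise.

As far as these compounds go, whether the number climbs gradually with length or jumps at one length remains open between propyl and pentyl, and a butyl chain on the core of compound 3 would settle this. A hexyl chain, or an amine at the chain end, would show how far the trend extends and whether it depends on an all-carbon chain.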